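Cyclohexyl urea at the acylguanidine terminus of the series

A few compounds are considered here, and "the series" means these few. Any claim that something is new, unique, unknown or untested is made for them only; others in the source may bear on it.

Compound 2 `CCCNC(=O)/N=C(\N)NCCCc1sc(N)nc1C` is the propyl urea of the shared core. Among the compounds with values here, in a functional assay on HEK293T cells for agonist activity at histamine H2 receptor (Homo sapiens), read by beta-arrestin recruitment (on this read-out lower numbers stand for an effect already at smaller amounts and higher numbers for an effect only at larger amounts of compound), compound 2 gives 170 nM, the second highest of the three numbers known. The nearest neighbour is compound 3 `Cc1ccc(CC(C)CNC(=O)/N=C(\N)NCCCc2sc(N)nc2C)cc1`, which gives 132 nM; the step of a 1.3-fold lower number from compound 2 to compound 3 (0.11 log units; within the scatter) lies within the scatter. The furthest is compound 1 `Cc1nc(N)sc1CCCN/C(N)=N/C(=O)NCC(C)CCc1ccccc1`, which gives 355 nM; the step of a 2.1-fold lower number from compound 1 to compound 2 (0.32 log units; beyond the scatter) is modest but beyond the scatter, as is a 2.7-fold lower number from compound 1 to compound 3 (0.43 log units; beyond the scatter).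

Compound 4 `Cc1nc(N)sc1CCCN/C(N)=N/C(=O)NC1CCCCC1` differs from compound 2 by cyclohexyl in place of propyl on an amide-type nitrogen. Within the data shown here, none of the measured steps closes a chain into a ring; the nearest analogue is the removal of the phenethyl branch in a 2.1-fold lower number from compound 1 to compound 2 (0.32 log units; beyond the scatter) and the addition of a 4-methylbenzyl branch in a 1.3-fold lower number from compound 2 to compound 3 (0.11 log units; within the scatter), both on a chain carbon rather than on the amide-type nitrogen. Those steps show that the nitrogen substituent tolerates sizeable change with at most modest movement, so for compound 4 a step of about a 1.1-fold lower number from compound 2 to compound 4 (0.05 log units; within the scatter) is expected, most likely within the scatter and with no firm direction. Compound 4 is therefore estimated at 150 nM in this assay, with a range from 60 nM to 400 nM.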

Compound 4, half-maximal effective concentration: 389 nM
The estimate for compound 4 lay 2.6-fold (0.41 log units) below the measured number, within the range that was stated.
By their numbers in this assay, from the lowest: compounds 3 and 2 (each within the scatter of the next); then compounds 1 and 4 (each within the scatter of the next).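

Cyclohexyl in place of propyl on an amide-type nitrogen gives the first measured step at this nitrogen substituent, and in this assay it is modest but beyond the scatter: a 2.3-fold higher number from compound 2 to compound 4 (0.36 log units; beyond the scatter). Added carbon alone does not account for this pattern, since the addition of a 4-methylbenzyl branch on a saturated chain carbon stays within the scatter, a 1.3-fold lower number from compound 2 to compound 3 (0.11 log units; within the scatter), so the earlier tolerance on the chain does not carry over to this change on the nitrogen. Nothing available on these compounds explains why the six-membered ring moves the number in this direction.

The compounds shown leave open whether the step follows the ring itself or only the larger number of carbons, and an open-chain hexyl group on the same nitrogen would separate the two. A cyclopentyl or a phenyl group in that place would show whether the step depends on ring size and on whether the ring is saturated.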